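The source may report more compounds than this note shows. Statements on the series, on what has been measured and on what is new or still open speak of the compounds shown alone.

Measured in a functional assay on LOX IMVI cells (Homo sapiens) for cytotoxicity, read by resazurin assay, with a stated time of 72 h; a higher number here means a weaker inhibitor, a lower number a stronger inhibitor:
compound 1 `COc1cc(/C=C/C(=O)Oc2ccc(OCc3c(-c4ccccc4)no[n+]3[O-])cc2)ccc1O` gives > 50000 nM, a limit of the assay.
compound 2 `COc1cc(/C=C/C(=O)OCCCCCO[N+](=O)[O-])ccc1OCCCCCO[N+](=O)[O-]` gives > 50000 nM, a limit of the assay.
compound 3 `COc1cc(/C=C/C(=O)OCCCCCO[N+](=O)[O-])ccc1O` gives > 50000 nM, a limit of the assay.

Compound 3 stands at the limit of > 50000 nM in this assay, at which 3 of the 3 values shown sit. Among the measured compounds shown here, every value shown in this assay is a limit, so compound 3 cannot be placed relative to compound 1 or compound 2, and the single one-place step, a step that the two limits leave unreadable from compound 2 to compound 3, gives no readable size. Compound 4 `COc1cc(/C=C/C(=O)OCCCCCCO[N+](=O)[O-])ccc1O` differs from compound 3 by (nitrooxy)methyl in place of nitrooxy on a saturated chain carbon, five bonds along the chain from an oxygen next to a carbonyl group. For the measured compounds named here, no measured step touches this lengthening of the chain; with all three values sitting at the limit, no step beyond the scatter is expected in either direction, and a limit is again the likely read-out. Compound 4 is therefore expected at 80000 nM, with a range from 40000 nM to 200000 nM, the expected step being a step that the limit leaves unreadable from compound 3 to compound 4.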

Compound 4, half-maximal inhibitory concentration: > 50000 nM
Compound 4 ended at the assay's limit; the forecaster's own chance of this, stated with the estimate: 85%; the middle value lies beyond the limit too.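

In this assay no new step can be read from compound 3 to compound 4, whose values are both limits of the assay. The compounds shown leave open at what concentration this series reaches half-maximal inhibition, and how the lengthening of the nitrooxy chain bears on it: the limit of > 50000 nM in this assay, at which 4 of the 4 values shown sit.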